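Swapping a Chloro for an Amine Side Chain

The source may hold more compounds than are shown below. What is called first, only, known or untested is meant among the compounds shown, and "the series" means these compounds.

Measured so far in a functional assay on DLD-1 cells (Homo sapiens) for cytotoxicity, read by MTT assay, with a stated time of 48 h; a lower number here means a stronger inhibitor, a higher number a weaker inhibitor:
compound 1 `CN(C)CCNc1ccnc2cc(OCc3ccc(F)cc3)ccc12` gives 810 nM
compound 2 `CCCCCCCCOc1ccc2c(Cl)ccnc2c1` gives 4500 nM
compound 3 `CCCCCCOc1ccc2c(Cl)ccnc2c1` gives 2660 nM

Compound 3 sits beside compound 2, within the scatter, and gives a higher number than compound 1, beyond it. Compound 4 `CCCCCCOc1ccc2c(NCCN(C)C)ccnc2c1` differs from compound 3 by (2-(dimethylamino)ethyl)amino in place of chloro on an aromatic carbon. For the measured compounds named here, the only measured step, a 1.7-fold lower number from compound 2 to compound 3 (0.23 log units; within the scatter), concerns chain length and does not touch this swap. Going by the values given here, compound 1 carries the same entering group and gives a lower number than compound 3, yet it also differs in its other chain, so no single step bears directly on the change. The estimate is therefore a moderate move towards a lower number, a 2.4-fold lower number from compound 3 to compound 4 (0.38 log units; beyond the scatter), with wide uncertainty. Compound 4 is expected at 1100 nM, between 300 nM and 4000 nM.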

Compound 4, half-maximal inhibitory concentration: 1870 nM
Beside the measured number, compound 4's estimate is 1.7-fold (0.23 log units) below it; the range from low to high includes it.
By their numbers in this assay, from the lowest: compound 1; then compounds 4, 3 and 2 (each within the scatter of the next, the first and the last beyond it).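

In this assay, placing (2-(dimethylamino)ethyl)amino in place of chloro on this aromatic carbon, opposite the ring nitrogen, gives a 1.4-fold lower number from compound 3 to compound 4 (0.15 log units; within the scatter), so this swap alone makes no clear difference. The clearer change lies in the oxygen-linked chain, where pentyl stands in place of 4-fluorophenyl, with a 2.3-fold higher number from compound 1 to compound 4 (0.36 log units; beyond the scatter). No measurement here explains either step.

On these data alone, whether a cyclic amine such as morpholine or piperazine would do more at this carbon remains open. So does the effect of a carboxylic acid at the end of the side chain.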